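The source may report more compounds than this note shows. Statements on the series, on what has been measured and on what is new or still open speak of the compounds shown alone.

Values so far in a functional assay on NCI/ADR-RES cells (Homo sapiens) for antiproliferative activity, read by MTT assay, with a stated time of 48 h; a higher number here means a weaker inhibitor, a lower number a stronger inhibitor

- compound 1 `Cc1c(Cc2ccccc2)c(=O)oc2cc(OCCOc3no[n+]([O-])c3S(=O)(=O)c3ccccc3)ccc12` gives 16.3 nM
- compound 2 `COc1cc(OCCOc2no[n+]([O-])c2S(=O)(=O)c2ccccc2)ccc1C(=O)/C=C/c1ccc(F)cc1` gives 47.9 nM
- compound 3 `COCCOc1no[n+]([O-])c1S(=O)(=O)c1ccccc1` gives 7850 nM

Compound 1 has the lowest number of the three, and its gaps to compound 2 and compound 3 both lie beyond the usual scatter. Compound 3 stands furthest from it.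

The next compound to be tested is compound 4 `CNS(=O)(=O)Nc1cccc(Cc2c(C)c3ccc(OCCOc4no[n+]([O-])c4S(=O)(=O)c4ccccc4)cc3oc2=O)c1` and it differs from compound 1 by one change: (methylsulfamoyl)amino in place of hydrogen on an aromatic carbon (in words, (methylsulfamoyl)amino in place of hydrogen on an aromatic carbon, so that phenyl becomes 3-((methylsulfamoyl)amino)phenyl). Within the data shown here, no pair of measured compounds differs in one place, so the data offer no direct measure of such a change.

Among the measured compounds shown here, the only guide is indirect. Compound 2 at 47.9 nM lies much closer to compound 1 than compound 3 does, even though compound 2 has a different group on the same side chain. A large loss in this assay is therefore not expected, and a small rise in the number, or none beyond the scatter, is the expectation.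

The estimated change is a 1.5-fold higher number from compound 1 to compound 4 (0.19 log units; within the scatter) in size and direction. In this assay compound 4 is estimated at 25 nM with an expected range from 7 nM to 90 nM (a wide range, given the lack of a measured step).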

Compound 4, half-maximal inhibitory concentration: 50.1 nM
Compound 4: the middle estimate sits 2.0-fold (0.30 log units) below what was measured; the measured number falls inside the stated range.
By their numbers in this assay, from the lowest: compound 1; then compounds 2 and 4 (each within the scatter of the next); then compound 3.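

In this assay the series gains its first single-place step, a 3.1-fold higher number from compound 1 to compound 4 (0.49 log units; beyond the scatter), and it concerns the phenyl of compound 1. The step lies beyond the scatter but is modest: with (methylsulfamoyl)amino on an aromatic carbon, meta to a large group, compound 4 still stands at 50.1 nM, so this phenyl accepts a substituent of this size without a collapse of activity in this cell line. Nothing measured here accounts for the rise in the number.

From the compounds shown here alone, with one step at one position, it remains open whether the rise belongs to the whole (methylsulfamoyl)amino group, to its methyl, or to the place on the ring. A plain amine or a methanesulfonamide on the same carbon, and the same (methylsulfamoyl)amino group on another carbon of the phenyl, would separate these readings and show whether any substituent here can match compound 1 at 16.3 nM.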